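A few compounds are considered here, and "the series" means these few. Any claim that something is new, unique, unknown or untested is made for them only; others in the source may bear on it.

Of the compounds shown here, three built on one shared core have been tested in an ADME assay on HEK293 cells (Homo sapiens) for cytotoxicity, read by CCK-8 assay, with a stated time of 48 h; a higher number here means a weaker inhibitor, a lower number a stronger inhibitor. Compound 1 `COc1ccc(/C=C\c2cc(OC)c(OC)c(OC)c2)cc1OCc1ccc(CN2CC[C@H](C(=O)O)C2)cc1` returns only a limit of this assay, namely > 50000 nM. Compound 2 `COc1ccc(/C=C\c2cc(OC)c(OC)c(OC)c2)cc1OCc1ccc(CN[C@H](C(=O)O)[C@H](C)O)cc1` likewise returns only a limit, > 50000 nM. Within the data shown here, compound 3 `COc1ccc(/C=C\c2cc(OC)c(OC)c(OC)c2)cc1OCc1ccc(C=O)cc1` is the single compound with an actual number, giving 46000 nM in this assay. The steps of an at least 1.0-fold lower number from compound 1 to compound 3 (0.03 log units; that floor lies within the scatter) and an at least 1.0-fold lower number from compound 2 to compound 3 (0.03 log units; that floor lies within the scatter) both stay within the scatter, and each rests on (the limit of > 50000 nM in this assay, at which 2 of the 3 values shown sit). Compound 4 `COc1ccc(/C=C\c2cc(OC)c(OC)c(OC)c2)cc1OCc1ccc(CNCCNC(C)=O)cc1` is next to be measured; it differs from compound 3 by ((2-acetamidoethyl)amino)methyl in place of formyl on an aromatic carbon. With the measured steps showing no movement beyond the scatter, the change to compound 4 is expected to give a step of a 1.1-fold higher number from compound 3 to compound 4 (0.04 log units; within the scatter). Compound 4 is therefore expected near 50000 nM, between 25000 nM and 100000 nM, and may well return only a limit.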

Compound 4, half-maximal inhibitory concentration: > 50000 nM
Compound 4 was reported as a limit; the forecaster's own chance of this, stated with the estimate: 60%; the middle value lies on the limit itself.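

Putting ((2-acetamidoethyl)amino)methyl in place of formyl on this aromatic carbon, para to a large group, gives in this assay an at least 1.0-fold higher number from compound 3 to compound 4 (0.03 log units; that floor lies within the scatter), so no real change can be claimed. The steps to compound 4 from compound 1 and compound 2 cannot be read, as each joins two limits. A chain without a carboxylic acid now reports the same limit as the two chains that carry one, and the series crowds there: the limit of > 50000 nM in this assay, at which 3 of the 4 values shown sit.

Going by these compounds, whether a plain primary amine or a longer chain on this aromatic carbon would give a readable number stays open.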